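The compounds below may be only part of what the source reports. "The series", "measured", "known", "first", "only" and "open" are said of these compounds alone.

Compound 1 `Cc1cccc(NC(=O)CSc2nnc(-c3ccoc3C)n2Cc2ccco2)c1C`: in a functional assay on CHO cells for antagonist activity at Orexin receptor type 2 (Homo sapiens), read by FLIPR and calcium flux (a lower number here means a stronger inhibitor, a higher number a weaker inhibitor), compound 1 gives only a limit, > 15800 nM.
Compound 2 `Cc1occc1-c1nnc(SCC(=O)Nc2cccc(Cl)c2)n1Cc1ccco1`: in this assay compound 2 gives 63.1 nM.
Compound 3 `CC(=O)c1ccc(NC(=O)CSc2nnc(-c3ccoc3C)n2Cc2ccco2)cc1`: in this assay compound 3 gives 31.6 nM.

Compound 3 thus holds the lowest of the two numbers, with compound 2 within the scatter of it, as a 2.0-fold lower number from compound 2 to compound 3 (0.30 log units; within the scatter) shows. Compound 4 `Cc1occc1-c1nnc(SCC(=O)Nc2ccc(N(C)C)cc2)n1Cc1ccco1` differs from compound 3 by dimethylamino in place of acetyl on an aromatic carbon. Three measured steps change the same aromatic ring and so bear on this one: an at least 250-fold lower number from compound 1 to compound 2 (2.39 log units; beyond the scatter) and an at least 500-fold lower number from compound 1 to compound 3 (2.69 log units; beyond the scatter) start from the limit of > 15800 nM in this assay, at which 1 of the 3 values shown sits, and are large, whereas a 2.0-fold lower number from compound 2 to compound 3 (0.30 log units; within the scatter), between two ring substituents that each give a number, is within the scatter. Because a 2.0-fold lower number from compound 2 to compound 3 (0.30 log units; within the scatter) is small, only a modest step is expected here, a 2.5-fold higher number from compound 3 to compound 4 (0.40 log units; beyond the scatter). Compound 4 is therefore estimated at 80 nM, in the range 20 nM to 400 nM.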

Compound 4, inhibition constant: 158 nM
Compound 4: the middle estimate sits 2.0-fold (0.30 log units) below what was measured; low and high end bracket the measured number.
By their numbers in this assay, from the lowest: compounds 3 and 2 (each within the scatter of the next); then compound 4. At a limit, above all of these: compound 1.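

At this ring carbon, the group itself matters: with the place held fixed, dimethylamino in place of acetyl moves the number beyond the scatter (a 5.0-fold higher number from compound 3 to compound 4 (0.70 log units; beyond the scatter)). The change from the 3-chlorophenyl amide is also beyond the scatter (a 2.5-fold higher number from compound 2 to compound 4 (0.40 log units; beyond the scatter)), unlike the earlier step between the two measured rings. The remaining step starts from a limit and so gives only a minimum size (an at least 100-fold lower number from compound 1 to compound 4 (2.00 log units; beyond the scatter)): (the limit of > 15800 nM in this assay, at which 1 of the 4 values shown sits).

With only acetyl and dimethylamino compared at this place, no trend can be drawn. On these data alone, how a primary amine, a methoxy group or a carboxylic acid would fare there remains open.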